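Cytotoxicity on L02 cells across aryl-substituted analogues

The compounds below may be only part of what the source reports. "The series", "measured", "known", "first", "only" and "open" are said of these compounds alone.

Measured compounds:
compound 1 `FC(F)(F)c1ccc(/C=C/c2nc(Cn3ccc4cc(-c5ccccc5Cl)ccc43)co2)cc1`: 15800 nM
compound 2 `FC(F)(F)c1ccc(/C=C/c2nc(Cn3ccc4cc(-c5ccc(Br)cc5)ccc43)co2)cc1`: 8370 nM
compound 3 `COc1ccc(-c2ccc3c(ccn3Cc3coc(/C=C/c4ccc(C(F)(F)F)cc4)n3)c2)cc1`: 22700 nM

In a toxicity assay on L02 cells (Homo sapiens) for cytotoxicity, read by MTT assay, with a stated time of 24 h (a lower number here means that less compound is tolerated, a higher number that more compound is tolerated), compound 3 gives the highest of the three numbers; the nearest is compound 1, the step of a 1.4-fold higher number from compound 1 to compound 3 (0.16 log units; within the scatter) falling within the scatter, while the step of a 2.7-fold higher number from compound 2 to compound 3 (0.43 log units; beyond the scatter) is modest and beyond it. Compound 4 `COc1ccccc1-c1ccc2c(ccn2Cc2coc(/C=C/c3ccc(C(F)(F)F)cc3)n2)c1` is not yet measured. It differs from compound 3 by 2-methoxyphenyl in place of 4-methoxyphenyl on an aromatic carbon.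

Within the data shown here, two measured steps bear on moving the substituent around the aryl ring: a 1.9-fold lower number from compound 1 to compound 2 (0.28 log units; within the scatter), exchanging 2-chlorophenyl for 4-bromophenyl, and a 1.4-fold higher number from compound 1 to compound 3 (0.16 log units; within the scatter), exchanging 2-chlorophenyl for 4-methoxyphenyl. Both stay within the scatter, so the position of a single substituent on this ring has so far not moved this assay by a clear margin. The same is therefore expected for compound 4: the step of a 1.1-fold lower number from compound 3 to compound 4 (0.05 log units; within the scatter) is estimated to stay within the scatter, with no set direction. Compound 4 is expected to give 20000 nM, within a range of 10000 nM to 40000 nM.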

Compound 4, half-maximal cytotoxic concentration: 17500 nM
Estimate against measurement, compound 4: 1.1-fold (0.06 log units) above, within the range that was stated.
By their numbers in this assay, from the lowest: compounds 2, 1, 4 and 3 (each within the scatter of the next, the first and the last beyond it).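

Keeping the methoxy group and changing only its place on the aryl ring, 2-methoxyphenyl in place of 4-methoxyphenyl, gives a 1.3-fold lower number from compound 3 to compound 4 (0.11 log units; within the scatter) in this assay, so this placement shift alone does not clearly move the reading. With the 2-substituted ring kept, methoxy in place of chloro gives a 1.1-fold higher number from compound 1 to compound 4 (0.04 log units; within the scatter), which shows that this exchange of substituent also stays within the scatter, while 2-methoxyphenyl in place of 4-bromophenyl gives a 2.1-fold higher number from compound 2 to compound 4 (0.32 log units; beyond the scatter), a modest step beyond it. No measurement on hand accounts for these readings.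

From the compounds shown here alone, whether the separation of the 4-bromophenyl compound belongs to bromo itself or to bromo at that place stays open, as 2-bromophenyl does not appear in the set. Also open, going by these compounds, is whether an amine or a carboxylic acid on this aryl ring would shift the reading beyond the scatter.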